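The compounds below may be only part of what the source reports. "The series", "measured", "known", "first", "only" and "open" are said of these compounds alone.

Three compounds built on a shared core appear here: compound 1 `C[C@]1(CN2CCc3nc(C4CCCCC4)ccc3C2)Cn2cc([N+](=O)[O-])nc2O1`, compound 2 `C[C@]1(CN2CCc3nc(C(F)(F)F)ccc3C2)Cn2cc([N+](=O)[O-])nc2O1` and compound 3 `C[C@]1(CN2CCc3nc(-c4ccc(C(F)(F)F)cc4)ccc3C2)Cn2cc([N+](=O)[O-])nc2O1`. In an ADME assay on Vero cells (Chlorocebus sabaeus) for cytotoxicity, read by MTT assay, with a stated time of 72 h (a lower number here means that less compound is tolerated, a higher number that more compound is tolerated), compound 1 gives "not determined" (no result reported), and compound 2 likewise gives "not determined" (no result reported), so neither offers a number to work with. Compound 3 was tested, but its outcome is a limit of the assay rather than a number: in this assay compound 3 gives > 32 ug/mL. Among the measured compounds shown here, that is all that is known of where compound 3 stands; of the three entries, one sits at the limit of > 32 ug/mL in this assay, at which 1 of the 3 values shown sits, and the other two carry no number at all, so no measured step between two compounds exists.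

Compound 4 `C[C@]1(CN2CCc3nc(-c4cc(F)cc(F)c4)ccc3C2)Cn2cc([N+](=O)[O-])nc2O1` differs from compound 3 in one place: 3,5-difluorophenyl in place of 4-(trifluoromethyl)phenyl on an aromatic carbon. With nothing measured to gauge such a swap in this assay, the step is expected to be none beyond the usual scatter, and the expected step is a number no higher from compound 3 to compound 4 (the limit leaves the size open). The estimated value for compound 4 is 32 ug/mL, with a range from 16 ug/mL to 64 ug/mL, and the most likely report for compound 4 is again a limit rather than a number.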

Compound 4, half-maximal cytotoxic concentration: > 32 ug/mL
Compound 4: a limit, no number; the forecaster's own chance of this, stated with the estimate: 70%; the middle value sits exactly at the limit.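

Compound 3 and compound 4 each give a limit of the assay rather than a number, so no step between them can be read: the limit of > 32 ug/mL in this assay, at which 2 of the 4 values shown sit.

The compounds shown leave open whether 3,5-difluorophenyl and 4-(trifluoromethyl)phenyl differ at all in this assay, and where compound 1 and compound 2 stand there.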